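Methyl in Place of Methoxy on the Benzyl Ring

The source may report more compounds than this note shows. Statements on the series, on what has been measured and on what is new or still open speak of the compounds shown alone.

Of the compounds shown here, two built on one shared core have been measured. Compound 1 `CC(C)(C)c1cc(/C=C/C(=O)NC2CCN(Cc3ccccc3)CC2)cc(C(C)(C)C)c1O` carries an unsubstituted benzyl group on its ring nitrogen; in an assay on isolated protein for inhibition of Amine oxidase [flavin-containing] B (Homo sapiens), read by fluorescence, with stated times of 15 min and 20 min (on this read-out higher numbers stand for weaker inhibition and lower numbers for stronger inhibition), compound 1 gives 33500 nM. Compound 2 `COc1ccc(CN2CCC(CCNC(=O)/C=C/c3cc(C(C)(C)C)c(O)c(C(C)(C)C)c3)CC2)cc1` carries a 4-methoxybenzyl group and a longer link to the amide; in this assay compound 2 gives 6700 nM, the lowest of the two numbers, and the gap up to compound 1 lies beyond the usual scatter of repeated measurements.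

Compound 3 `Cc1ccc(CN2CCC(CCNC(=O)/C=C/c3cc(C(C)(C)C)c(O)c(C(C)(C)C)c3)CC2)cc1` has not yet been measured. It differs from compound 2 in one place: methyl in place of methoxy on an aromatic carbon, para to a large group. Going by the values given here, no measured pair shows this exact change, so the expectation rests on the size of the change alone: a small group gives way to an even smaller one on the same aromatic carbon, and no shift beyond the scatter is expected in either direction. The expected step is a 1.0-fold lower number from compound 2 to compound 3 (0.01 log units; within the scatter). Compound 3 is therefore estimated to give about 6500 nM in this assay, with a likely range from 2500 nM to 16000 nM.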

Compound 3, half-maximal inhibitory concentration: 8900 nM
Estimate against measurement, compound 3: 1.4-fold (0.14 log units) below; the measured number falls inside the stated range.
By their numbers in this assay, from the lowest: compounds 2 and 3 (each within the scatter of the next); then compound 1.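

In this assay, replacing the methoxy with a methyl on the aromatic carbon para to a large group gives a 1.3-fold higher number from compound 2 to compound 3 (0.12 log units; within the scatter), so the two compounds cannot be told apart on this read-out. Going by these compounds alone, this is the first pair here that differs in one place only, and it shows that the methoxy oxygen, counted as a hydrogen-bond acceptor, can give way to a methyl at this position without a step beyond the scatter. Nothing available explains why this exchange leaves the numbers so close.

The compounds shown leave open whether a plain hydrogen at this position, on the same longer link, would also stay within the scatter, and so whether the gap between compound 1 and the other two belongs to the benzyl substituent or to the link. They also leave open how far this tolerance reaches, since an amine, a carboxylic acid or a longer chain at the same aromatic carbon would test it with groups much further from methoxy and methyl.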